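Chloro for fluoro on compound 1 in this series

The source may report more compounds than this note shows. Statements on the series, on what has been measured and on what is new or still open speak of the compounds shown alone.

Compound 1 `CC#CCn1c(N2CCC[C@@H](N)C2)cc(=O)n(Cc2ccc(F)c(C(=O)OC)c2)c1=O` carries a fluoro on an aromatic carbon and a methoxycarbonyl group. In an assay on isolated protein for inhibition of Dipeptidyl peptidase 9 (Homo sapiens), read by fluorescence, with stated times of 15 min and 20 min (on this read-out lower numbers stand for stronger inhibition and higher numbers for weaker inhibition), compound 1 gives only a limit, > 100 nM. Compound 2 `CC#CCn1c(N2CCC[C@@H](N)C2)cc(=O)n(Cc2ccc(F)c(C(=O)O)c2)c1=O` also returns a limit in this assay, > 100 nM. Compound 3 `CC#CCn1c(N2CCC[C@@H](N)C2)cc(=O)n(Cc2ccc(Br)c(C(=O)O)c2)c1=O` likewise stops at a limit in this assay, > 100 nM. Hence (the limit of > 100 nM in this assay, at which 3 of the 3 values shown sit), and the two measured steps, a step that the two limits leave unreadable from compound 1 to compound 2 and a step that the two limits leave unreadable from compound 2 to compound 3, cannot be read in size. Compound 4 `CC#CCn1c(N2CCC[C@@H](N)C2)cc(=O)n(Cc2ccc(Cl)c(C(=O)OC)c2)c1=O` differs from compound 1 by chloro in place of fluoro on an aromatic carbon. The step from compound 2 to compound 3 is the only one that touches this aromatic carbon, and it too is unreadable, so nothing here resolves a difference between fluoro and bromo, let alone fluoro and chloro. With every value sitting at the same limit, no step beyond the scatter in this assay can be expected in either direction, and most likely compound 4 also returns only a limit. The estimate for compound 4 is 300 nM, between 100 nM and 3000 nM, which means an expected step that the limit leaves unreadable from compound 1 to compound 4.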

Compound 4, half-maximal inhibitory concentration: > 100 nM
Compound 4 gave a limit, no number (the forecaster's own chance of this, stated with the estimate: 80%); the middle value is on the limit's open side.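

In this assay compound 4 gives > 100 nM, a limit and not a number, so its step from compound 1 cannot be read: the limit of > 100 nM in this assay, at which 4 of the 4 values shown sit.

The compounds shown leave open whether chloro in place of fluoro on the aromatic carbon changes inhibition at all, and in which direction.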